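This account rests on a few compounds, and the source may have more. Where it says the series, first, only, none or still open, it means among the compounds named here.

Of the compounds shown here, two sharing one core have been measured in a functional assay on HeLa cells (Homo sapiens) for inhibition, with a stated time of 72 h; a lower number here means a stronger inhibitor, a higher number a weaker inhibitor. There, compound 1 `NC1CCC(Nc2nc(NCc3ccc(-n4cccn4)cc3)c3ncn(C4CCCC4)c3n2)CC1` gives 170 nM and compound 2 `NC1CCC(Nc2nc(NCc3ccc(-c4cccc(F)c4)nc3)c3ncn(C4CCCC4)c3n2)CC1` gives 36 nM. Compound 2 therefore holds the lower of the two numbers, and its gap to compound 1 lies beyond the usual scatter. These two compounds differ in more than one place, so that gap cannot be assigned to any single group.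

Compound 3 `NC1CCC(Nc2nc(NCc3ccc(-c4ccco4)nc3)c3ncn(C4CCCC4)c3n2)CC1` has furan-2-yl in place of 3-fluorophenyl on an aromatic carbon, and the rest of compound 2 is unchanged: furan-2-yl in place of 3-fluorophenyl on an aromatic carbon. The swap sits on an aromatic carbon of a six-membered aromatic ring with 1 nitrogen, next to the ring nitrogen, para to a large group.

For the measured compounds named here, no measured pair isolates a change of this kind, so any forecast for this assay is tentative. A modest move to a higher number is expected, smaller than the gap separating the two measured compounds. The expected change is a 1.7-fold higher number from compound 2 to compound 3 (0.22 log units; within the scatter). Compound 3 is estimated at 60 nM, with an expected range of 22 nM to 160 nM.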

Compound 3, half-maximal inhibitory concentration: 30 nM
Compound 3: the middle estimate sits 2.0-fold (0.30 log units) above what was measured; measured number inside the range.
By their numbers in this assay, from the lowest: compounds 3 and 2 (each within the scatter of the next); then compound 1.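

In this assay, for the compounds shown here, the swap of 3-fluorophenyl for furan-2-yl on the aromatic carbon next to the ring nitrogen gives a 1.2-fold lower number from compound 2 to compound 3 (0.08 log units; within the scatter) and so provides the first single-change reading at this position: a five-membered aromatic ring with one oxygen and a six-membered aromatic ring of carbon only give values within the scatter of each other, although the entering group has fewer heavy atoms. The larger exchange of 4-(1H-pyrazol-1-yl)phenyl for 6-(furan-2-yl)pyridin-3-yl on the saturated chain carbon gives a 5.7-fold lower number from compound 1 to compound 3 (0.75 log units; beyond the scatter) and shows that replacing this whole unit moves the number beyond the scatter, whereas the furan-2-yl swap at its far end does not. No evidence at hand explains either step.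

Going by these compounds alone, whether an amine or a carboxylic acid on the same aromatic carbon would leave the number in this range remains open, as only two groups can be compared there. The whole-unit exchange also cannot show how much of its step belongs to the ring nitrogen and how much to the attached ring.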